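The source may report more compounds than this note shows. Statements on the series, on what has been measured and on what is new or still open speak of the compounds shown alone.

Cytotoxicity was followed in an ADME assay on HEp-2 cells (Homo sapiens) for cytotoxicity (a higher number here means that more compound is tolerated, a lower number that less compound is tolerated), across a small set of closely related compounds. Compound 1 `CC(C)CCn1c(Cn2c(=O)n(C(C)C)c3ccccc32)nc2cc(CN)ccc21` gives 3920 nM in this assay, while compound 2 `CC(C)CCn1c(Cn2c(=O)n(C(C)C)c3ccccc32)nc2cc(CO)ccc21`, which carries hydroxy in place of amino on a saturated chain carbon bound to an aromatic carbon, gives 31600 nM; the step of an 8.1-fold higher number from compound 1 to compound 2 (0.91 log units; beyond the scatter) shows that the change raised the tolerated concentration. Compound 3 `CC(C)CCn1c(Cn2c(=O)n(C(C)C)c3ccccc32)nc2ccc(CN)cc21` has the same atoms as compound 1 joined differently; the difference between the two cores is not broken down here. In this assay compound 3 gives 28100 nM, close to compound 2 and well apart from compound 1. Compound 4 `CC(C)CCn1c(Cn2c(=O)n(C(C)C)c3ccccc32)nc2ccc(CO)cc21` is not yet measured; it carries hydroxy in place of amino on a saturated chain carbon bound to an aromatic carbon, the same change already seen from compound 1 to compound 2. Resting on the single earlier step of an 8.1-fold higher number from compound 1 to compound 2 (0.91 log units; beyond the scatter), the step of a 3.2-fold higher number from compound 3 to compound 4 (0.51 log units; beyond the scatter) is expected, though with only one prior example and compound 3 already at a high number, a smaller rise would not surprise. In this assay compound 4 is therefore expected to give about 90000 nM, somewhere between 35000 nM and 250000 nM.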

Compound 4, half-maximal cytotoxic concentration: 81600 nM
Compound 4: the middle estimate sits 1.1-fold (0.04 log units) above what was measured; low and high end bracket the measured number.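

On the core of compound 3, hydroxymethyl in place of aminomethyl gives a 2.9-fold higher number from compound 3 to compound 4 (0.46 log units; beyond the scatter) in this assay, the same direction as on the core of compound 1. The direction of the change therefore carried over from one core to the other, but its size did not: the same change on two cores in this assay, an 8.1-fold higher number (0.91 log units; beyond the scatter) from compound 1 to compound 2 and a 2.9-fold higher number (0.46 log units; beyond the scatter) from compound 3 to compound 4, 2.8-fold (0.44 log units) apart, beyond the scatter of two such steps. These two pairs show that the core can alter how much this swap matters, but they do not show why the size differs, and they cannot say what the swap would do on a third core.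

The compounds shown also leave open how other groups in place of aminomethyl would behave, such as a carboxylic acid, a methyl ether or a longer chain ending in an amine. They tell only how the cells tolerate these compounds, and nothing about whether either swap changes any other property of the series.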